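A Chloro Added to a Well-Tolerated Compound

The compounds below may be only part of what the source reports. "The series", "measured", "known", "first", "only" and "open" are said of these compounds alone.

In an ADME assay on MRC5 cells (Homo sapiens) for cytotoxicity, read by fluorescence and resazurin assay, with a stated time of 3 days (a lower number here means that less compound is tolerated, a higher number that more compound is tolerated), compound 2 `O=C(Nc1cc(-c2ccccn2)n[nH]1)N1CCC(c2ccccc2)CC1` gives > 64000 nM, which is a limit and not a number. Compound 1 `O=C(Nc1cc(-c2ccccn2)n[nH]1)N1CCC(c2ccc(Cl)cc2)CC1` gives > 62000 nM, also a limit. Compound 3 `O=C(Nc1cc(-c2ccccn2)n[nH]1)N1CCC(c2cccc(Cl)c2)CC1` has chloro in place of hydrogen on an aromatic carbon, meta to a large group: chloro in place of hydrogen on an aromatic carbon. Among the measured compounds shown here, the one measured step that bears on this also exchanges chloro and hydrogen on an aromatic carbon, and it is a step that the two limits leave unreadable from compound 1 to compound 2. It offers no sign of a real effect, so no step beyond the scatter is expected in this assay. The expected step is an at least 1.0-fold lower number from compound 2 to compound 3 (0.02 log units; that floor lies within the scatter). Compound 3 is estimated at 60000 nM, with an expected range of 30000 nM to 70000 nM.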

Compound 3, half-maximal cytotoxic concentration: > 64000 nM
Compound 3: only a limit was reported; the forecaster's own chance of this, stated with the estimate: 80%; middle value at least 1.0-fold (0.02 log units) away from the limit.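

Among the compounds shown here, compound 1, compound 2 and compound 3 all give only limits, so no step between them can be read. The compounds shown leave open whether chloro in place of hydrogen on an aromatic carbon changes the result in this assay at all.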